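This account rests on a few compounds, and the source may have more. Where it says the series, first, only, none or still open, it means among the compounds named here.

In an ADME assay on a cell-free system (plasma, Homo sapiens) for metabolic stability, read by LC-MS (a lower number here means that the compound disappears faster, a higher number that the compound lasts longer), compound 3 `CCCCCOC(=O)c1cccc(-c2cc(C(=O)Nc3ccncc3)ccc2CN)c1` gives 0.967 h while compound 2 `CCCCCCOC(=O)c1cccc(-c2cc(C(=O)Nc3ccncc3)ccc2CN)c1` gives 0.833 h and compound 1 `CCCCOC(=O)c1cccc(-c2cc(C(=O)Nc3ccncc3)ccc2CN)c1` gives 0.367 h as its half-life. Compound 3 and compound 2 cannot be told apart, since a 1.2-fold higher number from compound 2 to compound 3 (0.06 log units; within the scatter) stays within the scatter. Both stand clear of compound 1, with a 2.6-fold higher number from compound 1 to compound 3 (0.42 log units; beyond the scatter) and a 2.3-fold higher number from compound 1 to compound 2 (0.36 log units; beyond the scatter) as the two steps beyond it.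

Compound 4 `CCCOC(=O)c1cccc(-c2cc(C(=O)Nc3ccncc3)ccc2CN)c1` follows from compound 3 through hydrogen in place of ethyl on a saturated chain carbon, three bonds along the chain from an oxygen next to a carbonyl group and the same difference reads pentyl to propyl. Compound 1 offers the closest guide. It differs from compound 3 by one methyl on the same chain, and a 2.6-fold higher number from compound 1 to compound 3 (0.42 log units; beyond the scatter) shows that its shorter chain goes with the lower number. Three compounds make no steady trend, and compound 2 goes against a simple rise with chain length because a 1.2-fold higher number from compound 2 to compound 3 (0.06 log units; within the scatter) shows no gain. Among the measured compounds shown here, no measured compound has a chain as short as that of compound 4, so the extrapolation is uncertain. For the measured compounds named here, a modest fall is still expected, somewhat larger than the one separating compound 1 from compound 3. The expected change is a 3.2-fold lower number from compound 3 to compound 4 (0.51 log units; beyond the scatter) and would lie beyond the scatter. In this assay compound 4 is estimated at 0.3 h with an expected range from 0.12 h to 0.7 h as its half-life.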

Compound 4, half-life: 0.3 h
The estimate for compound 4 equals the measured number at the digits printed, within the range that was stated.
By their numbers in this assay, from the lowest: compounds 4 and 1 (each within the scatter of the next); then compounds 2 and 3 (each within the scatter of the next).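

In this assay, compound 4 shows that the shortest chain here, propyl, stays clearly apart from the two longest, with a 3.2-fold lower number from compound 3 to compound 4 (0.51 log units; beyond the scatter) and a 2.8-fold lower number from compound 2 to compound 4 (0.44 log units; beyond the scatter), while a 1.2-fold lower number from compound 1 to compound 4 (0.09 log units; within the scatter) leaves it indistinguishable from the butyl chain of compound 1. The four chains therefore form two groups rather than a steady trend, with propyl and butyl in compounds 4 and 1 on one side and pentyl and hexyl in compounds 3 and 2 on the other, and ethyl in place of hydrogen gives a comparable rise from either of the shorter chains: the same change on two cores in this assay, a 2.3-fold higher number (0.36 log units; beyond the scatter) from compound 1 to compound 2 and a 3.2-fold higher number (0.51 log units; beyond the scatter) from compound 4 to compound 3, 1.4-fold (0.15 log units) apart, within the scatter of two such steps A single methyl at the chain end, by contrast, gives no readable change within either group: the same change on two cores in this assay, a 1.2-fold higher number (0.06 log units; within the scatter) from compound 2 to compound 3 and a 1.2-fold lower number (0.09 log units; within the scatter) from compound 1 to compound 4, 1.4-fold (0.15 log units) apart, within the scatter of two such steps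

The compounds shown leave open whether a methyl or ethyl chain would sit with the propyl and butyl chains or lower still, and whether a heptyl or longer chain would keep the higher numbers. They also leave open how a branched chain such as isopropyl or tert-butyl, or a chain carrying a ring such as benzyl, would behave at this position.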